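The source may hold more compounds than are shown below. What is called first, only, known or untested is meant among the compounds shown, and "the series" means these compounds.

Measured in a physicochemical assay for lipophilicity, using the shake flask method, at pH 7.4; on this read-out lower numbers stand for lower lipophilicity and higher numbers for higher lipophilicity:
- compound 1 `O=C(O)COc1ccc(NC(=O)COc2ccccc2)cc1F`: -1.25
- compound 2 `CC(Oc1ccccc1)C(=O)Nc1ccc(OCC(=O)O)c(F)c1`: -0.18
- compound 3 `CC(Oc1cccc(C(F)(F)F)c1)C(=O)Nc1ccc(OCC(=O)O)c(F)c1`: "not determined" (no result reported)

Of the two compounds with a number, compound 2 stands higher, and compound 3 offers no comparison. Compound 4 `Cc1ccc(OC(C)C(=O)Nc2ccc(OCC(=O)O)c(F)c2)cc1C` differs from compound 2 by 3,4-dimethylphenyl in place of phenyl on an oxygen on a saturated carbon. Among the measured compounds shown here, only one measured step bears on this, and it is a rough guide: a number 1.07 log units higher from compound 1 to compound 2 (beyond the scatter), a large step that came from methyl in place of hydrogen on a saturated chain carbon, a different place in the molecule. An upward step of similar size is expected, estimated as a number 0.93 log units higher from compound 2 to compound 4 (beyond the scatter). For compound 4 the estimated value is 0.75, with an expected range from 0.25 to 1.25.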

Compound 4, distribution coefficient: 0.33
Compound 4: middle estimate off by 0.42 log units, on the high side; measured number inside the range.
By their numbers in this assay, from the lowest: compound 1; then compound 2; then compound 4.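

In this assay, among the compounds shown here, the aromatic ring on the oxygen proves to be a second place where the number responds: 3,4-dimethylphenyl in place of phenyl gives a number 0.51 log units higher from compound 2 to compound 4 (beyond the scatter) as a modest step, whereas the only earlier step, at a saturated chain carbon, was large. No measurement shown explains this rise.

Going by these compounds, how much each of the two methyl groups contributes remains open, as does what a methoxy group or an amine on that ring would give. The step to compound 3 cannot be read.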